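The source may report more compounds than this note shows. Statements on the series, on what has been measured and on what is new or still open speak of the compounds shown alone.

Compound 3 `CC(C)c1ccc(NC(=O)N2CCN(c3ncccc3[N+](=O)[O-])CC2)cc1` is a piperazine urea, and in a functional assay on HEK293 cells for antagonist activity at transient receptor potential cation channel subfamily V member 1 (Rattus norvegicus) (a higher number here means a weaker inhibitor, a lower number a stronger inhibitor), compound 3 gives 190 nM. Going by the values given here, of the three numbers known, this is the lowest, though compound 2 `O=C(Nc1ccc(Oc2ccccc2)cc1)N1CCN(c2ncccc2C(F)(F)F)CC1`, which in this assay gives 258 nM, lies within the usual scatter of it, and only compound 1 `Cc1ccc(NC(=O)N2CCN(c3ncccc3C(F)(F)F)CC2)cc1`, which in this assay gives 556 nM, stands clearly higher.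

Compound 4 `CC(C)c1ccc(NC(=O)N2CCN(c3ncccc3Br)CC2)cc1` differs from compound 3 in one place: bromo in place of nitro on an aromatic carbon. Among the compounds with values here, no measured step bears directly on this change. Within the data shown here, the single step known, a 2.2-fold lower number from compound 1 to compound 2 (0.33 log units; beyond the scatter), concerns the other aromatic ring and is modest in size. Compound 2 and compound 3 differ in two places at once, so their values only show that two different substituents on the pyridine ring can sit close together in this assay. With nothing against it, one expects little movement beyond the scatter, so the step of a 1.4-fold higher number from compound 3 to compound 4 (0.14 log units; within the scatter) is estimated as small. Compound 4 is therefore expected to give about 260 nM, within a range from 80 nM to 850 nM.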

Compound 4, half-maximal inhibitory concentration: 4.6 nM
Estimate against measurement, compound 4: 57-fold (1.75 log units) above; measured number below the stated range.
By their numbers in this assay, from the lowest: compound 4; then compounds 3 and 2 (each within the scatter of the next); then compound 1.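

In this assay, the change from 3-nitropyridin-2-yl to 3-bromopyridin-2-yl gives a 41-fold lower number from compound 3 to compound 4 (1.62 log units; beyond the scatter) on the six-membered aromatic ring with 1 nitrogen. Going by these compounds alone, this shows that the place ortho to a large group, two atoms from the ring nitrogen, can shift the number far more than the only earlier step, a 2.2-fold lower number from compound 1 to compound 2 (0.33 log units; beyond the scatter), did on the other aromatic ring, and no earlier pair differed at this place alone. No measurement shown here accounts for the size of this step.

From the compounds shown here alone, it remains open whether chloro, methoxy or an amine at this place would give a number close to that of compound 4 or close to that of compound 3. Also open, going by these compounds, is whether trifluoromethyl would do the same on the core of compound 4, and whether phenoxy in place of isopropyl would keep the low number.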